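Removing the chloro group from the butyl compound

The source may report more compounds than this note shows. Statements on the series, on what has been measured and on what is new or still open speak of the compounds shown alone.

Values in a functional assay on EOL1 cells (Homo sapiens) for inhibition, read by fluorescence, with a stated time of 72 h; a higher number here means a weaker inhibitor of growth, a lower number a stronger inhibitor of growth:
compound 1 `CCCCCCn1cnc2c(Nc3ccc(Cl)cc3)nc(N[C@H]3CC[C@H](N)CC3)nc21` gives 440 nM
compound 2 `N[C@H]1CC[C@H](Nc2nc(Nc3ccc(Cl)cc3)c3ncn(C4CCCCC4)c3n2)CC1` gives 140 nM
compound 3 `CCCCn1cnc2c(Nc3ccc(Cl)cc3)nc(N[C@H]3CC[C@H](N)CC3)nc21` gives 50 nM

Compound 3 holds the lowest number of the three, with the gaps (a 2.8-fold lower number from compound 2 to compound 3 (0.45 log units; beyond the scatter)) and (an 8.8-fold lower number from compound 1 to compound 3 (0.94 log units; beyond the scatter)) both beyond the scatter. Compound 4 `CCCCn1cnc2c(Nc3ccccc3)nc(N[C@H]3CC[C@H](N)CC3)nc21` carries hydrogen in place of chloro on an aromatic carbon. Among the compounds with values here, no measured step touches this place, since all three change the group on the aromatic nitrogen. Those steps give only a rough guide to size, and the direction has no direct support. With compound 3 at the low end (50 nM), a modest move to a higher number is expected (a 2.4-fold higher number from compound 3 to compound 4 (0.38 log units; beyond the scatter)). Compound 4 is estimated at 120 nM (range 30 nM to 400 nM).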

Compound 4, concentration for 50% growth inhibition: 20 nM
Beside the measured number, compound 4's estimate is 6.0-fold (0.78 log units) above it, outside the stated range (below it).
By their numbers in this assay, from the lowest: compound 4; then compound 3; then compound 2; then compound 1.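

In this assay, the chloro group of compound 3 is not needed for growth inhibition: hydrogen at this aromatic carbon gives a lower number (a 2.5-fold lower number from compound 3 to compound 4 (0.40 log units; beyond the scatter)). Within the data shown here, this is the first reading at this place, since the earlier steps changed only the group on the aromatic nitrogen. No supporting data bear on the reason for this shift.

Going by these compounds, whether fluoro, methoxy or an amine at this place would match hydrogen remains open. Also open, on these data alone, is whether removing chloro gives a similar shift with the hexyl or cyclohexyl group on the aromatic nitrogen.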